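Compound 4: bromo in place of methoxy on the aryl ether

A few compounds are considered here, and "the series" means these few. Any claim that something is new, unique, unknown or untested is made for them only; others in the source may bear on it.

Measured compounds:
compound 1 `C=CCOc1c(C)c(C)c2c(c1C)CCC(C)(COc1ccc(/C=C3\SC(=O)NC3=O)cc1OC)O2` gives 34% in a functional assay on MCF7 cells (Homo sapiens), tested at 2.5 uM; on this read-out lower numbers stand for a stronger effect and higher numbers for a weaker effect at the one concentration tested.
compound 2 `CC(C)=CCOc1c(C)c(C)c2c(c1C)CCC(C)(COc1ccc(/C=C3\SC(=O)NC3=O)cc1F)O2` gives 95% in this assay.
compound 3 `CC(C)=CCOc1c(C)c(C)c2c(c1C)CCC(C)(COc1ccc(/C=C3\SC(=O)NC3=O)cc1)O2` gives 76% in this assay.

Compound 1 stands lowest of the three and so shows the strongest effect in this assay; compound 2 and compound 3 both lie above it beyond the scatter. Compound 4 `C=CCOc1c(C)c(C)c2c(c1C)CCC(C)(COc1ccc(/C=C3\SC(=O)NC3=O)cc1Br)O2` differs from compound 1 by bromo in place of methoxy on an aromatic carbon. Within the data shown here, no measured step exchanges methoxy for bromo. Among the measured compounds shown here, the one single-change step, a number 19 percentage points lower from compound 2 to compound 3 (beyond the scatter), shows that hydrogen in place of fluoro at this carbon lowered the number, so the fluoro compound had the weaker effect. Compound 1 also differs from compound 2 and compound 3 elsewhere, so this is only a loose guide. A weaker effect is therefore expected for compound 4, a step of a number 26 percentage points higher from compound 1 to compound 4 (beyond the scatter) in this assay. Compound 4 is estimated at 60%, expected between 35% and 90%.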

Compound 4, a percentage reported as activity, at one concentration (the size of the read-out at that concentration, not a potency): 102%
For compound 4 the middle estimate is 42 percentage points below the measured one; measured number above the stated range.
By their numbers in this assay, from the lowest: compound 1; then compound 3; then compounds 2 and 4 (each within the scatter of the next).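

Bromo in place of methoxy on this aromatic carbon gives a number 68 percentage points higher from compound 1 to compound 4 (beyond the scatter) in this assay. With everything else held constant, this single exchange removes the clear effect seen with methoxy, so the read-out depends strongly on the group at this carbon, ortho to a large group. Nothing measured here accounts for the size of this step.

From the compounds shown here alone, it remains open whether a hydroxy, an ethoxy or an amine at this carbon would keep the effect of compound 1 or lose it as compound 4 does.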